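A few compounds are considered here, and "the series" means these few. Any claim that something is new, unique, unknown or untested is made for them only; others in the source may bear on it.

Measured so far: compound 1, `CC(C)CCn1nc(-c2cccs2)c(O)c(C2=NS(=O)(=O)c3cc(CS(C)(=O)=O)ccc3N2)c1=O`, gives 0.467 h in an in vitro ADME assay on microsomes from liver (Homo sapiens) for metabolic stability, tested at 5 uM; a lower number here means that the compound disappears faster, a higher number that the compound lasts longer. Compound 2, `CCC(C)CCn1nc(-c2cccs2)c(O)c(C2=NS(=O)(=O)c3cc(NS(C)(=O)=O)ccc3N2)c1=O`, is recorded only as a limit in this assay, > 1 h.

Compound 2 thus stands at the upper edge of what this assay reports, a limit rather than a number, as shown by the limit of > 1 h in this assay, at which 1 of the 2 values shown sits. Compound 1 sits at a measured half-life lower than that edge. For the measured compounds named here, no single-point step connects these two, so the account says no more of them than their two values show.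

The next compound, compound 3, `CS(=O)(=O)Nc1ccc2c(c1)S(=O)(=O)N=C(c1c(O)c(-c3cccs3)nn(CC3(C(F)(F)F)CC3)c1=O)N2`, has not yet been tested. It differs from compound 2 in one place: 1-(trifluoromethyl)cyclopropyl in place of 2-methylbutyl on a saturated chain carbon bound to an aromatic nitrogen. Going by the values given here, no measured step in this assay bears on this change, so the size of the step can only be expected, not read off. The account expects compound 3 to stay near the limit where compound 2 sits, with a step from compound 2 to compound 3 estimated at a step that the limit leaves unreadable from compound 2 to compound 3, none beyond the usual scatter. The half-life of compound 3 in this assay is accordingly estimated at 1.2 h, within a range from 0.5 h to 3 h.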

Compound 3, half-life: > 1 h
Compound 3: no number, only a limit; the forecaster's own chance of this, stated with the estimate: 55%; the middle value does not contradict the limit.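

Compound 3, like compound 2, is recorded in this assay only as a limit and not as a number, so no step can be read from compound 2 to compound 3: the limit of > 1 h in this assay, at which 2 of the 3 values shown sit.

The compounds shown leave open how long compound 2 and compound 3 actually last, and whether 1-(trifluoromethyl)cyclopropyl in place of 2-methylbutyl alters the half-life at all.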